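Shortening the side chain of a three-compound alkyne series

The compounds below may be only part of what the source reports. "The series", "measured", "known", "first", "only" and "open" are said of these compounds alone.

Compound 1 `CC(C)CC(C#Cc1cccc(C(=O)NCc2ccccc2C(F)(F)F)c1)N(O)C(N)=O` gives 600 nM in an assay for inhibition of Polyunsaturated fatty acid 5-lipoxygenase (Homo sapiens), read by HPLC, with stated times of 15 min and 10 min (a lower number here means a stronger inhibitor, a higher number a weaker inhibitor), the lowest of the three numbers in hand. Compound 3 `CC(C#Cc1cccc(C(=O)NCc2ccccc2OC(F)(F)F)c1)N(O)C(N)=O` gives 1000 nM in this assay, a number within the scatter of compound 1, so no order between the two can be claimed. Compound 2 `CC(C#Cc1cccc(C(=O)NCc2ccc(F)cc2C(F)(F)F)c1)N(O)C(N)=O` gives 1300 nM in this assay, a higher number that lies beyond the scatter. Compound 4 `C[C@H](C#Cc1cccc(C(=O)NCc2ccccc2C(F)(F)F)c1)N(O)C(N)=O` is not yet measured and differs from compound 1 in one place: 1-(carbamoyl(hydroxy)amino)ethyl in place of 1-(carbamoyl(hydroxy)amino)-3-methylbutyl on a triple-bonded carbon. Within the data shown here, compound 2 and compound 3 also carry the shorter group, but each differs elsewhere as well, so no single step isolates this change. A modest rise is expected, a 1.5-fold higher number from compound 1 to compound 4 (0.18 log units; within the scatter). Compound 4 is thus estimated at 900 nM in this assay, with a range from 350 nM to 2300 nM.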

Compound 4, half-maximal inhibitory concentration: 600 nM
The estimate for compound 4 lay 1.5-fold (0.18 log units) above the measured number; measured number inside the range.
By their numbers in this assay, from the lowest: compounds 1, 4, 3 and 2 (each within the scatter of the next, the first and the last beyond it).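

Putting 1-(carbamoyl(hydroxy)amino)ethyl in place of 1-(carbamoyl(hydroxy)amino)-3-methylbutyl on a triple-bonded carbon gives no change at the digits printed from compound 1 to compound 4 (within the scatter) in this assay. Among these compounds, compounds 2 and 3 carried the shorter group only alongside other differences, so this step is the first to show that, on the core of compound 1, the shorter group can stand in for the longer one without a change beyond the scatter. Nothing at hand explains this result.

Going by these compounds, how a phenyl or cyclopropyl group at this position would read remains open. On these data alone, compound 4 has a defined stereocentre, so the opposite configuration also remains open.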